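The compounds below may be only part of what the source reports. "The series", "measured", "known", "first", "only" and "open" are said of these compounds alone.

Measured so far in a physicochemical assay for solubility, read by nephelometry, at pH 7.4; on this read-out lower numbers stand for lower solubility and higher numbers for higher solubility:

- Compound 1 `COc1cccc(NC(=O)c2nnn(Cc3ccc([S+](C)[O-])cc3)c2N)c1`: > 250000 nM, a limit of the assay and not a number
- Compound 2 `COc1cccc(NC(=O)c2nnn(Cc3ccc(C(C)C)cc3)c2N)c1`: 14000 nM
- Compound 3 `COc1cccc(NC(=O)c2nnn(Cc3ccccc3)c2N)c1`: 16000 nM

Compound 3 reads 16000 nM, and the gap to its nearest neighbour is a 1.1-fold higher number from compound 2 to compound 3 (0.06 log units; within the scatter). As far as these compounds go, compound 1 gives only a limit, so its exact place on the scale is unknown.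

The next compound is compound 4 `COc1cccc(NC(=O)c2nnn(Cc3ccc(-n4cccn4)cc3)c2N)c1`. It carries 1H-pyrazol-1-yl in place of hydrogen on an aromatic carbon.

Two measured steps also exchange hydrogen and a group on an aromatic carbon. One is a 1.1-fold higher number from compound 2 to compound 3 (0.06 log units; within the scatter), so swapping isopropyl for hydrogen left no visible mark. The other is an at least 15-fold lower number from compound 1 to compound 3 (1.19 log units; beyond the scatter), which is large but rests on a limit. Neither departing group is 1H-pyrazol-1-yl, so both are loose guides, and they disagree on size. Compound 2, at 14000 nM, shows that a new group need not shift the number at all. The large step has been seen only once, so no change beyond the scatter is the likeliest outcome, with a slight lean towards a lower number.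

In this assay, the expected step is a 1.5-fold lower number from compound 3 to compound 4 (0.16 log units; within the scatter). Compound 4 is estimated at 11000 nM, with an expected range from 3500 nM to 30000 nM.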

Compound 4, solubility: 20000 nM
The estimate for compound 4 lay 1.8-fold (0.26 log units) below the measured number; the measured number falls inside the stated range.
By their numbers in this assay, from the lowest: compounds 2, 3 and 4 (each within the scatter of the next). At a limit, above all of these: compound 1.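

In this assay, 1H-pyrazol-1-yl on the aromatic carbon para to a large group brings a whole five-membered aromatic ring to this position, yet the comparison with hydrogen gives a 1.3-fold higher number from compound 3 to compound 4 (0.10 log units; within the scatter), and the comparison with isopropyl gives a 1.4-fold higher number from compound 2 to compound 4 (0.15 log units; within the scatter). Hydrogen, isopropyl and this ring therefore give numbers that cannot be told apart here, a pattern that holds for compounds 2, 3 and 4 and that compound 1 goes against. The remaining step, an at least 12-fold lower number from compound 1 to compound 4 (1.09 log units; beyond the scatter), is large and shows that the ring does not carry this series to the level of compound 1, but that step rests on a limit and not on a number: the limit of > 250000 nM in this assay, at which 1 of the 4 values shown sits.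

Still open, as far as these compounds go, is whether an amine, a carboxylic acid or a sulfone on this carbon would read like compound 1 or like compounds 2, 3 and 4. From the compounds shown here alone, the true size of the gap to compound 1 also stays unknown, so it cannot yet be said how far a single group at this position can move the number.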